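The source may report more compounds than this note shows. Statements on the series, on what has been measured and on what is new or still open speak of the compounds shown alone.

Compound 1 `Cc1nn(-c2ncnc3nc[nH]c23)c2c1C(OCc1cc(F)cc3c1OCOC3)CC(=O)N2`: 1.5 nM
Compound 2 `CCC(C(=O)NC1CC(=O)Nc2c1c(C)nn2-c1ncnc2nc[nH]c12)c1ccccc1`: 5 nM

Of the compounds shown here, two built on the same core have been tested in a functional assay on HEK293 cells for agonist activity at G-protein coupled receptor 39 (Homo sapiens), read by scintillation proximity assay and inositol phosphate accumulation, with a stated time of 75 min, in the presence of a further agent that is not named here; on this read-out lower numbers stand for an effect already at smaller amounts and higher numbers for an effect only at larger amounts of compound. Compound 1 gives 1.5 nM, the lower of the two numbers. Compound 2 gives 5 nM, and the gap between the two lies beyond the usual scatter, so compound 1 stands as the more potent of the pair as far as these two numbers go.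

Compound 3 `Cc1nn(-c2ncnc3nc[nH]c23)c2c1C(OCc1ccccc1F)CC(=O)N2` has not been measured in this assay. It differs from compound 1 in a single place: a group of 7 heavy atoms (6 carbon, 1 fluorine; one six-membered aromatic ring of carbon only) in place of a group of 11 heavy atoms (8 carbon, 2 oxygen, 1 fluorine; one six-membered non-aromatic ring with 2 hetero atoms, one six-membered aromatic ring of carbon only), on a saturated chain carbon bound to an oxygen on a saturated carbon. Going by the values given here, no pair of measured compounds differing in one place is available, so the size of this step cannot be read from a neighbour. The group that enters keeps the aromatic ring and the fluorine, while the six-membered non-aromatic ring with 2 hetero atoms is lost, and the step from compound 1 to compound 3 is therefore expected to go toward a higher number, of modest size, possibly not beyond the scatter. Compound 3 is estimated at 4 nM, with a range from 1.5 nM to 12 nM, which means an expected step of a 2.7-fold higher number from compound 1 to compound 3 (0.43 log units; beyond the scatter).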

Compound 3, half-maximal effective concentration: 4 nM
The estimate for compound 3 equals the measured number at the digits printed, and the stated range covers the measured number.
By their numbers in this assay, from the lowest: compound 1; then compounds 3 and 2 (each within the scatter of the next).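

Going by these compounds alone, at the saturated chain carbon bound to an oxygen on a saturated carbon, this is the first change that can be read on its own, since the two earlier compounds differed in more than one place. In this assay, replacing the larger group with 2-fluorophenyl gives a 2.7-fold higher number from compound 1 to compound 3 (0.43 log units; beyond the scatter), a modest step that shows the six-membered non-aromatic ring with 2 hetero atoms and its 2 hydrogen-bond acceptors can leave this position while compound 3 still gives 4 nM in the nanomolar range. The ring and the acceptors leave together in this single step, so their shares cannot be separated, and nothing at hand explains the size of the change.

The compounds shown leave open how much of the number depends on the fluorine, as a plain phenyl group has no value here to set against 2-fluorophenyl. They also leave open how this position would respond to a group of another kind, such as an amine, a carboxylic acid or a longer alkyl chain in place of 2-fluorophenyl.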